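Swapping the ketone-side aryl of compound 1 for a chlorophenyl

The source may hold more compounds than are shown below. What is called first, only, known or untested is meant among the compounds shown, and "the series" means these compounds.

Compound 1 `COc1ccc(C(=O)/C=C/c2cc(-c3cc(OC)c(OC)c(OC)c3)n3nc(-c4ccccc4)cc3n2)cc1OC` belongs to a small set of chalcone-like molecules built on a shared core. In a functional assay on MDA-MB-231 cells (Homo sapiens) for antiproliferative activity, read by MTT assay, with a stated time of 24 h (a higher number here means a weaker inhibitor, a lower number a stronger inhibitor), compound 1 gives 18300 nM, the highest of the three numbers available. Among the compounds with values here, compound 2 `COc1ccc(-c2cc(/C=C/C(=O)c3ccc(OC)c(OC)c3)nc3cc(-c4ccccc4)nn23)cc1` gives 8700 nM, and the step of a 2.1-fold lower number from compound 1 to compound 2 (0.32 log units; beyond the scatter) is the only single-point change with a measured size. Within the data shown here, compound 3 `COc1ccc(-c2cc(/C=C/C(=O)c3ccccc3)nc3cc(-c4ccccc4)nn23)cc1OC` gives 11800 nM, a number that stands within the scatter of compound 1, but no single-change step links these two.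

Compound 4 `COc1cc(-c2cc(/C=C/C(=O)c3ccc(Cl)cc3)nc3cc(-c4ccccc4)nn23)cc(OC)c1OC` is a new member. The change from compound 1 is 4-chlorophenyl in place of 3,4-dimethoxyphenyl on a carbonyl carbon. Among the measured compounds shown here, no measured step touches this position, so nothing here tells how large such a change is; the only sized step, from compound 1 to compound 2, concerns a different place. The expectation is therefore for no step beyond the scatter, with the step of a 1.5-fold lower number from compound 1 to compound 4 (0.18 log units; within the scatter) as the estimate. Compound 4 is expected to give 12000 nM, in a range from 5000 nM to 30000 nM.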

Compound 4, half-maximal inhibitory concentration: 32500 nM
Beside the measured number, compound 4's estimate is 2.7-fold (0.43 log units) below it; measured number above the stated range.
By their numbers in this assay, from the lowest: compounds 2, 3, 1 and 4 (each within the scatter of the next, the first and the last beyond it).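

Within the data shown here, this is the first measured change at this position: 4-chlorophenyl in place of 3,4-dimethoxyphenyl on a carbonyl carbon gives a 1.8-fold higher number from compound 1 to compound 4 (0.25 log units; within the scatter) in this assay. The step shows that the position accepts a swap of the whole ring without a change that can be told from assay scatter, even though the leaving group has 2 hydrogen-bond acceptors and the entering group has none. No evidence here explains this result.

A single step cannot show whether other groups on this ring, such as an amine or a carboxylic acid, would give a step beyond the scatter. As far as these compounds go, it also remains open whether the same swap would give a similar step on compound 2, which carries 4-methoxyphenyl in place of 3,4,5-trimethoxyphenyl.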